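Chloro for fluoro on the aromatic ring of compound 2

A few compounds are considered here, and "the series" means these few. Any claim that something is new, unique, unknown or untested is made for them only; others in the source may bear on it.

Measured so far in an ADME assay on DU-145 cells (Homo sapiens) for cytotoxicity, read by MTT assay, with a stated time of 72 h; on this read-out higher numbers stand for weaker inhibition and lower numbers for stronger inhibition
compound 1 (`COc1ccc(C2=C(c3cc(OC)c(OC)c(OC)c3)C(=O)C(OC(C)=O)C2)cc1`) gives > 100 ug/mL as a limit of the assay
compound 2 (`COc1ccc(C2=C(c3cc(OC)c(OC)c(OC)c3)C(=O)C(OC(C)=O)C2)cc1F`) gives 16 ug/mL
compound 3 (`COc1ccc(C2=C(c3cc(OC)c(OC)c(OC)c3)C(=O)C(O)C2)cc1F`) gives 27 ug/mL

Within the data shown here, compound 2 and compound 3 hold the only two actual numbers, and they lie within the scatter of each other, as a 1.7-fold higher number from compound 2 to compound 3 (0.23 log units; within the scatter) shows. Compound 1 stands at a limit and has no number.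

Compound 4 (`COc1ccc(C2=C(c3cc(OC)c(OC)c(OC)c3)C(=O)C(OC(C)=O)C2)cc1Cl`) has not yet been measured. The change from compound 2 to compound 4 (chloro in place of fluoro on an aromatic carbon) is chloro in place of fluoro on an aromatic carbon, ortho to a methoxy group.

The step that bears on this change sits on that same carbon: an at least 6.2-fold lower number from compound 1 to compound 2 (0.79 log units; beyond the scatter) came with fluoro in place of hydrogen. The other step, hydrogen in place of acetyl on an oxygen on a saturated carbon, lies elsewhere on the molecule. Among the measured compounds shown here, no measured step exchanges one halogen for another, so its size here is unknown.

Compound 4 keeps a halogen on the carbon where compound 2 with 16 ug/mL has one, so no step beyond the scatter is expected in this assay for this exchange. The expected outcome is a 1.1-fold higher number from compound 2 to compound 4 (0.05 log units; within the scatter) on this estimate.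

For compound 4 the estimate is 18 ug/mL with an expected range from 7 ug/mL to 50 ug/mL in this assay.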

Compound 4, half-maximal inhibitory concentration: 64 ug/mL
Estimate against measurement, compound 4: 3.6-fold (0.55 log units) below; the measured number lies above the stated range.
By their numbers in this assay, from the lowest: compounds 2 and 3 (each within the scatter of the next); then compound 4. At a limit, above all of these: compound 1.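

In this assay, the new result shows that the halogen on this carbon matters and not merely its presence: chloro in place of fluoro gives a 4.0-fold higher number from compound 2 to compound 4 (0.60 log units; beyond the scatter). The drop in the number that came with fluoro therefore cannot be assumed for chloro, and chloro in place of hydrogen gives only an at least 1.5-fold lower number from compound 1 to compound 4 (0.19 log units; that floor lies within the scatter), a floor that does not establish a real difference between the 3-chloro-4-methoxyphenyl compound and the unsubstituted one. This comparison can go no further, as compound 1 stands at a limit of the assay: the limit of > 100 ug/mL in this assay, at which 1 of the 4 values shown sits.

The compounds shown leave open how other groups on this carbon would read in this assay, such as bromo, methyl, a nitrile or an amine, and so whether fluoro is a special case or one end of a wider series. They also leave open whether the chloro compound would follow the fluoro pair when hydrogen replaces acetyl on the oxygen, since compound 3 is the only free alcohol among them.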